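The compounds below may be only part of what the source reports. "The series", "measured", "known", "first", "only" and "open" are said of these compounds alone.

Three compounds share a skeleton in which a pyrazole ring carries both a trimethoxyphenyl or dimethoxyphenyl group and an unsaturated ketone arm, and all three were tested in a functional assay on NCI-H522 cells (Homo sapiens) for inhibition, read by sulforhodamine B assay, with a stated time of 48 h; a higher number here means a weaker inhibitor of growth, a lower number a stronger inhibitor of growth. Compound 1, `COc1cc(-c2cc(/C=C/C(=O)c3ccc(N)cc3)[nH]n2)cc(OC)c1OC`, gives 1620 nM. Compound 3, `COc1ccc(-c2cc(/C=C/C(=O)c3ccc(N)cc3)[nH]n2)cc1OC`, gives 1650 nM. Compound 2, `COc1ccc(C(=O)/C=C/c2cc(-c3cc(OC)c(OC)c(OC)c3)n[nH]2)cc1OC`, gives 180 nM and is the strongest growth inhibitor of the three, since its steps to both others are beyond the scatter.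

The change from compound 3 to compound 1 is methoxy in place of hydrogen on an aromatic carbon, and it made a 1.0-fold lower number from compound 3 to compound 1 (0.01 log units; within the scatter). The change from compound 1 to compound 2 made a 9.0-fold lower number from compound 1 to compound 2 (0.95 log units; beyond the scatter). The difference between the cores of compound 2 and compound 3 is not broken down here.

Compound 4, `COc1cc(C(=O)/C=C/c2cc(-c3cc(OC)c(OC)c(OC)c3)n[nH]2)cc(OC)c1OC`, has not yet been measured in this assay. It differs from compound 2 by methoxy in place of hydrogen on an aromatic carbon. This is the same change that took compound 3 to compound 1, at a place described in the same words, and that earlier step stayed within the scatter. Because the earlier step was a 1.0-fold lower number from compound 3 to compound 1 (0.01 log units; within the scatter), the step to compound 4 is expected to be small as well, about a 1.1-fold higher number from compound 2 to compound 4 (0.02 log units; within the scatter). Compound 4 is therefore estimated to give 190 nM in this assay, most likely between 80 nM and 450 nM.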

Compound 4, concentration for 50% growth inhibition: 520 nM
Estimate against measurement, compound 4: 2.7-fold (0.44 log units) below; the measured number lies above the stated range.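

In this assay, methoxy in place of hydrogen on an aromatic carbon gave a 2.9-fold higher number from compound 2 to compound 4 (0.46 log units; beyond the scatter), while the same change elsewhere in the series gave a 1.0-fold lower number from compound 3 to compound 1 (0.01 log units; within the scatter), and the two steps do differ: the same change on two cores in this assay, a 1.0-fold lower number (0.01 log units; within the scatter) from compound 3 to compound 1 and a 2.9-fold higher number (0.46 log units; beyond the scatter) from compound 2 to compound 4, 2.9-fold (0.47 log units) apart, beyond the scatter of two such steps

So a change that made no clear difference in one pair of compounds cannot be assumed to do nothing in another, and here the added methoxy goes with a weaker growth inhibitor. Going by these compounds alone, this is only one comparison of two pairs, however, and the shared description "on an aromatic carbon" does not mean that the new group sits in the same setting in both, so the gap cannot be assigned to the core alone, and the numbers give no reason for it.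

On these data alone, it remains open whether a different group at the position of the new methoxy in compound 4, such as a fluorine atom, a hydroxyl group or an ethoxy group, would give a number closer to that of compound 2 or to that of compound 4. A further pair carrying this same change on another core would also be needed to tell whether the step seen here or the earlier one is the more typical.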